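The source may hold more compounds than are shown below. What is called first, only, known or untested is meant among the compounds shown, and "the series" means these compounds.

In a functional assay on NCI-H661 cells (Homo sapiens) for antiproliferative activity, read by MTT assay, with a stated time of 72 h (a lower number here means a stronger inhibitor, a higher number a weaker inhibitor), compound 1 `O=C(CCCCCCc1nc(-c2ccc(F)cc2)no1)NO` gives 19400 nM and compound 2 `O=C(CCCCCCc1nc(-c2ccccc2Cl)no1)NO` gives 10300 nM as its reading. Within the data shown here, these two numbers lie within the usual scatter of each other, so compound 2 stands level with its only measured neighbour and the pair cannot be ranked. Compound 3 `O=C(CCCCCCc1nc(-c2cccs2)no1)NO` keeps the shared core and differs from compound 2 in one group, with thiophen-2-yl in place of 2-chlorophenyl on an aromatic carbon. Among the measured compounds shown here, the only measured step that bears on this change is the exchange of one substituted phenyl for another (a 1.9-fold lower number from compound 1 to compound 2 (0.27 log units; within the scatter)), and that step stayed within the scatter. For the measured compounds named here, no compound with a five-membered aromatic ring in this place has been measured yet, so this single step is a thin guide. From the compounds shown here alone, on that evidence, no step beyond the scatter is expected in this assay and the direction remains open. The expected change is therefore small (a 1.2-fold higher number from compound 2 to compound 3 (0.07 log units; within the scatter)). Compound 3 is estimated at 12000 nM with an expected range from 4500 nM to 30000 nM in this measurement.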

Compound 3, half-maximal inhibitory concentration: 9460 nM
Estimate against measurement, compound 3: 1.3-fold (0.10 log units) above; the measured number falls inside the stated range.
By their numbers in this assay, from the lowest: compounds 3, 2 and 1 (each within the scatter of the next, the first and the last beyond it).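

In this assay, the position on the aromatic carbon now carries a five-membered aromatic ring with 1 hetero atom rather than a six-membered aromatic ring of carbon only, and thiophen-2-yl in place of 2-chlorophenyl gives a 1.1-fold lower number from compound 2 to compound 3 (0.04 log units; within the scatter), so this exchange of ring size leaves the reading level. Among these compounds, the exchange of 4-fluorophenyl for thiophen-2-yl gives a 2.1-fold lower number from compound 1 to compound 3 (0.31 log units; beyond the scatter), the first step at this position that clears the scatter, though only modestly, and since compound 2 stands within the scatter of both other compounds, this is the only pair that can be ranked. Nothing measured here accounts for either step.

From the compounds shown here alone, all three groups at this position are aromatic rings, so it remains open whether an amine or a carboxylic acid on the same carbon would move the reading clearly beyond the scatter. Among the compounds shown here, it is also open whether a longer chain in place of the one the three compounds share would change the reading by more than these ring exchanges do.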